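The compounds below may be only part of what the source reports. "The series", "measured", "known", "first", "only" and "open" are said of these compounds alone.

- Compound 1 `Cc1nc2cnccc2n1CC1CCN(C(=O)CCc2ccccc2)CC1` gives > 5 mg/kg (a limit of the assay, not a number)
- Compound 2 `COc1ccccc1CCC(=O)N1CCC(Cn2c(C)nc3cnccc32)CC1` gives 0.045 mg/kg
- Compound 3 `Cc1nc2cnccc2n1CC1CCN(C(=O)CC(C)(O)c2ccccc2)CC1` gives 0.043 mg/kg

All three results come from a functional assay on the whole organism (arterial blood) with Rattus norvegicus as the target (on this read-out higher numbers stand for an effect only at larger amounts of compound and lower numbers for an effect already at smaller amounts), and were obtained in the whole animal. For the measured compounds named here, compound 3 stands level with the only other exact number, since the step is a 1.0-fold lower number from compound 2 to compound 3 (0.02 log units; within the scatter) in this comparison.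

In compound 4 `Cc1nc2cnccc2n1CC1CCN(C(=O)CN(C)c2ccccc2)CC1` methyl(phenyl)amino takes the place of 1-hydroxy-1-phenylethyl on a saturated chain carbon bound to a carbonyl carbon (methyl(phenyl)amino in place of 1-hydroxy-1-phenylethyl on a saturated chain carbon bound to a carbonyl carbon).

Going by the values given here, two measured steps bear on this change, and both are large: an at least 110-fold lower number from compound 1 to compound 2 (2.04 log units; beyond the scatter) and also an at least 110-fold lower number from compound 1 to compound 3 (2.06 log units; beyond the scatter) as a second case. Compound 4 carries neither the methoxy of the first step nor the 1-hydroxy-1-phenylethyl of the second, so a higher number is expected, partway back towards the limit seen for compound 1. The size of that move is uncertain. The expected step is a 7.0-fold higher number from compound 3 to compound 4 (0.84 log units; beyond the scatter) as a rough estimate. For compound 4 the estimated dose is 0.3 mg/kg with an expected range from 0.03 mg/kg to 3 mg/kg in this read-out.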

Compound 4, dose for 50% inhibition: 0.31 mg/kg
Compound 4: the middle estimate sits 1.0-fold (0.01 log units) below what was measured, within the range that was stated.
By their numbers in this assay, from the lowest: compounds 3 and 2 (each within the scatter of the next); then compound 4. At a limit, above all of these: compound 1.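

Methyl(phenyl)amino in place of 1-hydroxy-1-phenylethyl on a saturated chain carbon bound to a carbonyl carbon gives a 7.2-fold higher number from compound 3 to compound 4 (0.86 log units; beyond the scatter) in this assay, and the same place compared with 2-methoxybenzyl gives a 6.9-fold higher number from compound 2 to compound 4 (0.84 log units; beyond the scatter). Up to now only groups carrying an oxygen had moved the number far from that of the benzyl compound, yet methyl(phenyl)amino, which has no oxygen, still keeps much of that gain, with an at least 16-fold lower number from compound 1 to compound 4 (1.20 log units; beyond the scatter). That last step is only a lower bound, since compound 1 stands at a limit of the assay, not a number: the limit of > 5 mg/kg in this assay, at which 1 of the 4 values shown sits.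

As far as these compounds go, the step from compound 3 swaps the hydroxy and the carbon for a nitrogen together, so the share of each in the change stays unknown. From the compounds shown here alone, how a carboxylic acid, a primary amine or a longer chain would read at this place also remains open.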